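A Halogen Swap on the Aniline of Compound 1

The source may hold more compounds than are shown below. What is called first, only, known or untested is meant among the compounds shown, and "the series" means these compounds.

Compound 1 `COc1cc2c(Nc3cccc(F)c3F)ncnc2c(OC)c1OC` stands only at a limit in a functional assay on SGC-7901 cells (Homo sapiens) for antiproliferative activity, read by MTT assay, with a stated time of 72 h; on this read-out lower numbers stand for stronger inhibition and higher numbers for weaker inhibition: compound 1 gives > 30000 nM, which is a limit of the assay rather than a number (the limit of > 30000 nM in this assay, at which 1 of the 2 values shown sits). For the measured compounds named here, its one measured neighbour, compound 2 `COc1cc2c(Nc3cc(F)ccc3Br)ncnc2c(OC)c1OC`, gives 18400 nM in this assay. The step from compound 1 to compound 2 amounts to an at least 1.6-fold lower number from compound 1 to compound 2 (0.21 log units; that floor lies within the scatter). The unmeasured compound 3 `COc1cc2c(Nc3ccc(Cl)cc3F)ncnc2c(OC)c1OC` differs from compound 1 by 4-chloro-2-fluorophenyl in place of 2,3-difluorophenyl on a nitrogen on an aromatic ring. Going by the values given here, only the step of an at least 1.6-fold lower number from compound 1 to compound 2 (0.21 log units; that floor lies within the scatter) bears on this change, and it shows that exchanging the 2,3-difluorophenyl for another phenyl bearing halogens moved the number down only to a floor that lies within the scatter. On that basis compound 3 is expected to fall in the same region as compound 2 rather than to move far. The step that this estimate means, an at least 1.5-fold lower number from compound 1 to compound 3 (0.17 log units; that floor lies within the scatter), is expected to be modest and downward. Compound 3 is therefore estimated at 20000 nM in this assay, with a range from 8000 nM to 50000 nM, and a real chance that only a limit is returned again.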

Compound 3, half-maximal inhibitory concentration: > 30000 nM
Compound 3 gave a limit, no number (the forecaster's own chance of this, stated with the estimate: 40%); at least 1.5-fold (0.17 log units) between middle value and limit.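

With 4-chloro-2-fluorophenyl on a nitrogen on an aromatic ring, compound 3 returns only a limit, as compound 1 does, in this assay: the limit of > 30000 nM in this assay, at which 2 of the 3 values shown sit.

The step between these two compounds cannot be read. For the compounds shown here, the one readable new step is an at least 1.6-fold higher number from compound 2 to compound 3 (0.21 log units; that floor lies within the scatter). Three phenyl groups bearing halogens have now stood at this place, and only the 2-bromo-5-fluorophenyl of compound 2 gave a number, yet the floor of its steps to compound 1 and compound 3 does not set it apart beyond the scatter, so the change from one halogen pattern to another has so far shown no clear gain.

The compounds shown leave open whether a phenyl carrying an amine or a carboxylic acid in place of the halogens, or a longer chain on this nitrogen, would bring a number well clear of the limit in this assay. They also leave open whether the bromine of compound 2 is what separates it from compound 1 and compound 3, as its ring differs from theirs in more than that one atom.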